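Oral Exposure in Rats After a Piperidine Substituent Swap

The compounds below may be only part of what the source reports. "The series", "measured", "known", "first", "only" and "open" are said of these compounds alone.

Measured compounds:
compound 1, `CCCCCOC(=O)N1CCN(C(=O)[C@H](CCC(=O)O)NC(=O)c2cc(N3CCC(COC)CC3)nc(-c3ccccc3)n2)CC1`: 61%
compound 2, `CCCCCOC(=O)N1CCN(C(=O)[C@H](CCC(=O)O)NC(=O)c2nc(-c3ccccc3)cc(N3CCC(COC)CC3)n2)CC1`: 6%

In an in vivo ADME assay on the whole organism (strain Sprague-Dawley) for pharmacokinetics, with Rattus norvegicus as the target, at a dose of 5 mg/kg by the oral route (on this read-out higher numbers stand for higher oral bioavailability and lower numbers for lower oral bioavailability), compound 1 gives 61%, the higher of the two numbers recorded, and compound 2 gives 6%, a gap beyond the scatter. Compound 3, `CCCCCOC(=O)N1CCN(C(=O)[C@H](CCC(=O)O)NC(=O)c2cc(N3CCC(C(=O)N(CC)CC)CC3)nc(-c3ccccc3)n2)CC1`, has not yet been measured in this assay. It differs from compound 1 as follows: diethylcarbamoyl in place of methoxymethyl on a saturated ring carbon. Going by the values given here, no measured pair shows the effect of such a change, so the direction is uncertain; a moderate fall is expected, a number 19 percentage points lower from compound 1 to compound 3 (beyond the scatter). Compound 3 is expected to give about 42% in this assay, within a range from 12% to 70%.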

Compound 3, oral bioavailability: 38%
Compound 3: middle estimate off by 4 percentage points, on the high side, and the stated range covers the measured number.
By their numbers in this assay, from the lowest: compound 2; then compound 3; then compound 1.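

Going by these compounds alone, replacing methoxymethyl with diethylcarbamoyl on a saturated ring carbon gives a number 23 percentage points lower from compound 1 to compound 3 (beyond the scatter) in this assay, the first measured step at this position. The step is modest, so this larger group lowers oral bioavailability without abolishing it. Nothing available here bears on the reason for the fall. As far as these compounds go, whether the fall follows from the carbonyl or from the two ethyl groups remains open. So does how a dimethylcarbamoyl group, a carboxylic acid or an amine on this ring carbon would read in this assay.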